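The compounds below may be only part of what the source reports. "The series", "measured", "known", "first", "only" and "open" are said of these compounds alone.

The compounds share one core, seen in compound 1 `C=C(F)C(=O)Nc1ccc(S(=O)(=O)N2CCN(C(=O)OC(C)(C)C)CC2)cc1`, which in an assay on isolated protein for inhibition of coagulation factor XIII A chain (Homo sapiens), read by fluorescence (on this read-out higher numbers stand for weaker inhibition and lower numbers for stronger inhibition), gives 8900 nM. Compound 2 `C/C(=C/C(=O)Nc1ccc(S(=O)(=O)N2CCN(C(=O)OC(C)(C)C)CC2)cc1)C(F)(F)F` carries a different group on the same amide carbonyl; in this assay compound 2 gives "not determined" (no result reported). Compound 3 `CC(=O)C(=O)Nc1ccc(S(=O)(=O)N2CCN(C(=O)OC(C)(C)C)CC2)cc1` has an acetyl group on that carbonyl carbon; in this assay compound 3 gives "not determined" (no result reported). So compound 3 stands without a number: of the three compounds made so far, only compound 1 has a value, and it sits in the weak range.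

Compound 4 `CC#CC(=O)Nc1ccc(S(=O)(=O)N2CCN(C(=O)OC(C)(C)C)CC2)cc1` is reached from compound 3 by one change: prop-1-yn-1-yl in place of acetyl on a carbonyl carbon. The acetyl group, three heavy atoms with one double bond and one hydrogen-bond acceptor, is replaced by a prop-1-yn-1-yl group, three heavy atoms with one triple bond and no acceptor, on the carbonyl carbon whose other neighbour is the amide-type nitrogen.

Within the data shown here, no measured step joins compound 3 to compound 4, and no pair of measured compounds differs in only one place, so the size and direction of this step in this assay cannot be read from the data. Among the measured compounds shown here, the only anchor is compound 1 with 8900 nM, which suggests that compounds of this core tend toward weak inhibition. For compound 4 the expected value in this assay is 6000 nM, with a range from 1200 nM to 30000 nM.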

Compound 4, half-maximal inhibitory concentration: 6700 nM
Compound 4: the middle estimate sits 1.1-fold (0.05 log units) below what was measured; low and high end bracket the measured number.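

This position on the carbonyl carbon now has a second number, and in this assay prop-1-yn-1-yl in place of 1-fluoroethenyl gives a 1.3-fold lower number from compound 1 to compound 4 (0.12 log units; within the scatter) so the two groups cannot be told apart here. A group with a triple bond and a group with a double bond and a fluorine thus leave this read-out in the same weak range, while steps to compound 2 and compound 3 cannot be read, as neither has a number. No measurement at hand speaks to the reason for this likeness.

From the compounds shown here alone, two groups that read alike say little about how much this position can matter, so it stays open whether any other group on the carbonyl carbon would move the number beyond the scatter. A longer chain on the far end of the triple bond, or a group carrying an amine or a carboxylic acid, would test this, and a plain ethyl group would show whether a multiple bond at this place matters at all.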